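Working notes on the series: compound 2 to compound 4

A few compounds are considered here, and "the series" means these few. Any claim that something is new, unique, unknown or untested is made for them only; others in the source may bear on it.

Measured so far:
compound 1 `COc1ccc(/C=C/C(=O)c2c(O)cc(O)cc2OC)cc1OC`: 18500 nM
compound 2 `COc1cc(OC)c(C(=O)/C=C/c2ccc(O)cc2)c(OC)c1`: 37000 nM
compound 3 `COc1cc(OC)c(C(=O)/C=C/c2ccc(O)c(OC)c2)c(OC)c1`: 17000 nM

In a functional assay on HepG2 cells (Homo sapiens) for inhibition, read by MTT assay, with a stated time of 72 h (a lower number here means a stronger inhibitor, a higher number a weaker inhibitor), compound 2 stands at the highest of the three numbers, with compound 1 within the scatter of it and compound 3 beyond it. Compound 4 `COc1cc(OC)c(C(=O)/C=C/c2ccc([N+](=O)[O-])cc2)c(OC)c1` differs from compound 2 as follows: nitro in place of hydroxy on an aromatic carbon. Within the data shown here, the only measured step, a 2.2-fold lower number from compound 2 to compound 3 (0.34 log units; beyond the scatter), concerns a different change and does not bear on a nitro in place of hydroxy; no measured pair shows that change. The step from compound 2 to compound 4 is therefore expected to be a 1.2-fold lower number from compound 2 to compound 4 (0.09 log units; within the scatter), with no direction readable from the data, that is none beyond the scatter. Compound 4 is estimated at 30000 nM, with a range of 10000 nM to 90000 nM.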

Compound 4, half-maximal inhibitory concentration: 9400 nM
Compound 4: middle estimate off by 3.2-fold (0.50 log units), on the high side; measured number outside the range, below it.
By their numbers in this assay, from the lowest: compounds 4, 3, 1 and 2 (each within the scatter of the next, the first and the last beyond it).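

In this assay, the hydroxy on the aromatic carbon para to a large group can be exchanged: nitro there gives a 3.9-fold lower number from compound 2 to compound 4 (0.60 log units; beyond the scatter), so a hydrogen-bond donor at this position is not needed for activity in this assay. Among these compounds, the only earlier step, a 2.2-fold lower number from compound 2 to compound 3 (0.34 log units; beyond the scatter), was a methoxy in place of hydrogen that left this hydroxy untouched. No evidence at hand accounts for the new step.

From the compounds shown here alone, whether the step comes from losing hydroxy or from gaining nitro remains open. Going by these compounds, how an amine or a carboxylic acid would compare at this position also remains open.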